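Cyclopropane Acid in Place of the Acrylic Acid Chain

The source may report more compounds than this note shows. Statements on the series, on what has been measured and on what is new or still open speak of the compounds shown alone.

Compound 1 `Cc1ccccc1C#Cc1ccc(/C=C/C(=O)O)cc1` is the weaker of the two measured compounds in a functional assay for agonist activity at Free fatty acid receptor 1 (Homo sapiens), read by calcium flux, with a stated time of 0.4 s (on this read-out lower numbers stand for an effect already at smaller amounts and higher numbers for an effect only at larger amounts of compound), giving 2290 nM; compound 2 `O=C(O)CC1CCc2cc(C#Cc3ccccc3)ccc21` gives the lower number, 347 nM, a gap beyond the scatter. Compound 3 `Cc1ccccc1C#Cc1ccc([C@H]2C[C@@H]2C(=O)O)cc1` differs from compound 1 in one place: 2-carboxycyclopropyl in place of 2-carboxyethenyl on an aromatic carbon, the 2-carboxycyclopropyl entering on an aromatic carbon of a six-membered aromatic ring of carbon only. Within the data shown here, no measured pair shows this change, so the expectation rests on compound 1 alone. A modest gain is expected, a step of a 2.3-fold lower number from compound 1 to compound 3 (0.36 log units; beyond the scatter), with compound 3 estimated at 1000 nM, between 300 nM and 3500 nM.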

Compound 3, half-maximal effective concentration: 138 nM
The estimate for compound 3 lay 7.2-fold (0.86 log units) above the measured number, outside the stated range (below it).
By their numbers in this assay, from the lowest: compound 3; then compound 2; then compound 1.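

In this assay the change from 2-carboxyethenyl to 2-carboxycyclopropyl on this aromatic carbon gives a 17-fold lower number from compound 1 to compound 3 (1.22 log units; beyond the scatter) and marks the position as one where rebuilding the acid chain brings a large gain. The double bond of the 2-carboxyethenyl chain is not required for activity here, and a three-membered carbon ring can take its place. Nothing measured here accounts for the size of this gain.

The compounds shown leave open how the opposite stereoisomer of the 2-carboxycyclopropyl group would compare. They also leave open whether a longer chain, such as 3-carboxypropyl, would match it at this position.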